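Swapping Chloro for Amino on the Shared Core

The source may hold more compounds than are shown below. What is called first, only, known or untested is meant among the compounds shown, and "the series" means these compounds.

For the measured compounds named here, in an assay on isolated protein (strain Sprague-Dawley) for inhibition of Amine oxidase [flavin-containing] B (Rattus norvegicus), read by spectrophotometry, with a stated time of 5 min (a lower number here means a stronger inhibitor, a higher number a weaker inhibitor), compound 2 `O=c1cc(Cl)c2ccc(OCc3cccc(Cl)c3)cc2o1` gives 20.9 nM, the lowest of the two numbers measured so far. Compound 1 `CCOC(=O)COc1cc(=O)oc2cc(OCc3cccc(Cl)c3)ccc12` gives 1820 nM in this assay. Compound 3 `Nc1cc(=O)oc2cc(OCc3cccc(Cl)c3)ccc12` has not been measured; it differs from compound 2 by amino in place of chloro on an aromatic carbon. Going by the values given here, only the step from compound 1 to compound 2 bears on this change, and because an 87-fold lower number from compound 1 to compound 2 (1.94 log units; beyond the scatter) accompanied the move to the small chloro, a modest loss is expected on replacing it with amino, a 3.8-fold higher number from compound 2 to compound 3 (0.58 log units; beyond the scatter). Compound 3 is therefore expected to give 80 nM, within 20 nM to 400 nM.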

Compound 3, half-maximal inhibitory concentration: 47.9 nM
For compound 3 the middle estimate is 1.7-fold (0.22 log units) above the measured one, within the range that was stated.
By their numbers in this assay, from the lowest: compound 2; then compound 3; then compound 1.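

In this assay, the change from chloro to amino on this aromatic carbon brings a 2.3-fold higher number from compound 2 to compound 3 (0.36 log units; beyond the scatter), while replacing (ethoxycarbonyl)methoxy with amino brings a 38-fold lower number from compound 1 to compound 3 (1.58 log units; beyond the scatter), in the same direction as chloro. The low numbers are therefore not confined to chloro, even though amino adds a hydrogen-bond donor and acceptor that chloro lacks. Nothing measured here explains the gap between chloro and amino. Still open, on these data alone, is where a hydroxyl, a methylamino or a methoxy group would fall at this position, and how far a longer chain could go before the numbers rise towards that of compound 1.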